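A few compounds are considered here, and "the series" means these few. Any claim that something is new, unique, unknown or untested is made for them only; others in the source may bear on it.

Measured compounds:
- compound 2, `Nc1cc(N)c2nc(-c3ccccc3)c(NCc3ccc(Cl)c(Cl)c3)nc2c1`: 70800 nM in a functional assay on 786-0 cells (Homo sapiens) for inhibition, read by sulforhodamine B assay, with a stated time of 48 h; a lower number here means that less compound is tolerated, a higher number that more compound is tolerated
- compound 1, `CCOC(=O)[C@H](CCC(=O)O)NC(=O)c1ccc(CNc2nc3cc(N)cc(N)c3nc2-c2ccccc2)cc1`: in this assay compound 1 reaches only < 100000 nM, which is a limit of the assay and not a number

Going by the values given here, compound 2 therefore stands as the holder of the single actual number in this assay; the other result sits at the limit of < 100000 nM in this assay, at which 1 of the 2 values shown sits, so there is no measured step against which to gauge it.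

Compound 3, `COc1ccc(CNc2nc3cc(N)cc(N)c3nc2-c2ccccc2)cc1`, has not yet been measured. It differs from compound 2 in one place: 4-methoxyphenyl in place of 3,4-dichlorophenyl on a saturated chain carbon bound to a nitrogen on an aromatic ring. Among the compounds with values here, no step between measured compounds covers such a change, so the expectation rests on compound 2 alone. With compound 2 at 70800 nM and the exchange confined to the substituent on the benzyl arm, a step of no more than modest size is expected from compound 2 to compound 3, a 1.2-fold higher number from compound 2 to compound 3 (0.08 log units; within the scatter), pointing toward a somewhat higher number, and possibly none beyond the usual scatter. Compound 3 is accordingly estimated at 85000 nM in this assay, within a range from 30000 nM to 200000 nM, with a real chance that only a limit is reported.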

Compound 3, concentration lethal to 50% of the cells: < 100000 nM
Compound 3: no number, only a limit; the forecaster's own chance of this, stated with the estimate: 35%; the middle value is on the limit's open side.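

In this assay compound 3 gives < 100000 nM, which is a limit of the assay and not a number, so no step can be read from compound 2 to compound 3. The compounds shown leave open whether 4-methoxyphenyl in place of 3,4-dichlorophenyl changes the value at all, and two of them share one result: the limit of < 100000 nM in this assay, at which 2 of the 3 values shown sit.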